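Cytotoxicity notes on an imidazopyrimidine amine pair

A few compounds are considered here, and "the series" means these few. Any claim that something is new, unique, unknown or untested is made for them only; others in the source may bear on it.

Measured so far:
compound 1 `CCCCOc1ccc(-c2nc3ncccn3c2NC2CCCCCC2)cc1` gives 26000 nM in a toxicity assay on A549 cells (Homo sapiens) for cytotoxicity, read by luminescence and CellTiter-Glo, with a stated time of 48 h; a lower number here means that less compound is tolerated, a higher number that more compound is tolerated
compound 2 `Fc1ccc(COc2ccc(-c3nc4ncccn4c3NC3CCCCC3)cc2)cc1` gives 24000 nM in this assay

In this assay compound 2 and compound 1 give numbers that lie within the scatter of each other, so neither stands apart. Compound 3 `c1ccc(-c2nc3ncccn3c2NC2CCCCC2)cc1` is not yet measured. It differs from compound 2 by hydrogen in place of (4-fluorobenzyl)oxy on an aromatic carbon. For the measured compounds named here, no measured pair shows a change of this kind, so the expected step is none beyond the scatter, with a slight lean toward a higher number. Compound 3 is therefore estimated at 35000 nM, range 15000 nM to 80000 nM, a step of a 1.5-fold higher number from compound 2 to compound 3 (0.16 log units; within the scatter).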

Compound 3, half-maximal cytotoxic concentration: 100000 nM
Beside the measured number, compound 3's estimate is 2.9-fold (0.46 log units) below it, and the stated range ends below it.
By their numbers in this assay, from the lowest: compounds 2 and 1 (each within the scatter of the next); then compound 3.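

Hydrogen in place of (4-fluorobenzyl)oxy on the aromatic carbon gives, in this assay, a 4.2-fold higher number from compound 2 to compound 3 (0.62 log units; beyond the scatter), the first step read at this position. For the compounds shown here, the group on this carbon therefore bears on how much compound is tolerated, which the earlier compounds, with no step between them, could not show. No evidence on the cause of this step is at hand.

Still open, going by these compounds, is whether the whole (4-fluorobenzyl)oxy group is needed for the lower number, or whether a methoxy group or an amine on this carbon would give the same.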